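From methoxy to chloro on the shared core

The source may report more compounds than this note shows. Statements on the series, on what has been measured and on what is new or still open speak of the compounds shown alone.

Measured in a functional assay on HeLa cells (Homo sapiens) for antiproliferative activity, read by MTT assay, with a stated time of 48 h; on this read-out higher numbers stand for weaker inhibition and lower numbers for stronger inhibition:
- compound 1 `COc1ccc2nc(NC(c3cn(-c4ccccc4)nc3-c3ccc(F)cc3)c3c(O)ccc4ccccc34)sc2c1` gives 4630 nM
- compound 2 `COc1ccc2nc(NC(c3cn(-c4ccccc4)nc3-c3cccc([N+](=O)[O-])c3)c3c(O)ccc4ccccc34)sc2c1` gives 6140 nM

Going by the values given here, only these two compounds have numbers so far, and they sit close together. Among the compounds with values here, the one measured step is a 1.3-fold higher number from compound 1 to compound 2 (0.12 log units; within the scatter), so compound 1 cannot be separated from its sole neighbour.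

Compound 3 `Oc1ccc2ccccc2c1C(Nc1nc2ccc(Cl)cc2s1)c1cn(-c2ccccc2)nc1-c1ccc(F)cc1` has not yet been measured. It departs from compound 1 at a single place, with chloro in place of methoxy on an aromatic carbon, turning 6-methoxy-1,3-benzothiazol-2-yl into 6-chloro-1,3-benzothiazol-2-yl.

The measured step bears on this only indirectly, since it swaps 4-fluorophenyl for 3-nitrophenyl elsewhere on the core and leaves the methoxy untouched. Within the data shown here, no measured pair tests the methoxy position. That one step shows a change at another place staying within the scatter, so no shift beyond the scatter is expected in this assay, though the range must stay wide.

The expected step is a 1.0-fold lower number from compound 1 to compound 3 (0.01 log units; within the scatter).

For compound 3 the estimated value is 4500 nM, with an expected range from 1700 nM to 12000 nM.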

Compound 3, half-maximal inhibitory concentration: 30100 nM
For compound 3 the middle estimate is 6.7-fold (0.83 log units) below the measured one; the whole stated range lies below it.
By their numbers in this assay, from the lowest: compounds 1 and 2 (each within the scatter of the next); then compound 3.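

Going by these compounds alone, the position carrying the methoxy, which no earlier pair had tested, proves sensitive in this assay: exchanging 6-methoxy-1,3-benzothiazol-2-yl for 6-chloro-1,3-benzothiazol-2-yl gives a 6.5-fold higher number from compound 1 to compound 3 (0.81 log units; beyond the scatter). Within the data shown here, the only earlier step, at a different place on the shared core, was a 1.3-fold higher number from compound 1 to compound 2 (0.12 log units; within the scatter), so this is the first change to separate two compounds, and it moves towards weaker inhibition. Nothing at hand accounts for this shift.

A single pair cannot show whether the methoxy itself supports the activity of compound 1 or whether chloro in particular is poorly tolerated; an ethoxy, a fluoro, an amine or plain hydrogen at the same place would help tell these two readings apart. Going by these compounds, it also remains open whether the exchange of methoxy for chloro would give a step of similar size on the 3-nitrophenyl compound 2, or whether its size depends on the 4-fluorophenyl group shared by compound 1 and compound 3.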